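Ethyl for hydrogen on the chain: two related steps

A few compounds are considered here, and "the series" means these few. Any claim that something is new, unique, unknown or untested is made for them only; others in the source may bear on it.

Measured compounds and values:
compound 1, `COc1ccc(N)c(C(=O)CCNC(C)=O)c1`: 30.7%
compound 2, `CCCC(=O)NCCC(=O)c1cc(OC)ccc1N`: 7.35%
compound 3, `CNC(=S)NCCC(O)c1cc(OC)ccc1N`: 76.6%

All three were tested in an assay for inhibition of Nitric oxide synthase, inducible (Homo sapiens), read by scintillation counting, with a stated time of 30 min, tested at 1 mM; a lower number here means less inhibition, a higher number more inhibition at the concentration tested (going by the name of the read-out). Among the compounds with values here, compound 3 gives the highest value of the three; compound 1 and compound 2 stand well below it, and the step of a number 23.4 percentage points lower from compound 1 to compound 2 (beyond the scatter) is the only measured step between compounds that differ in one place. That step is ethyl in place of hydrogen on a saturated chain carbon bound to a carbonyl carbon.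

How the core of compound 3 differs from that of compound 1 is not broken down here. Compound 4, `CCCNC(=S)NCCC(O)c1cc(OC)ccc1N`, has not yet been measured in this assay. It differs from compound 3 by ethyl in place of hydrogen on a saturated chain carbon bound to an amide-type nitrogen. Within the data shown here, this is the same kind of change as the one from compound 1 to compound 2, but not the same: in the measured pair the ethyl enters on a saturated chain carbon bound to a carbonyl carbon, whereas in compound 4 it enters on a saturated chain carbon bound to an amide-type nitrogen.

Among the measured compounds shown here, with only one measured instance of this kind of change, the expectation for compound 4 rests on it alone. Because a number 23.4 percentage points lower from compound 1 to compound 2 (beyond the scatter) is a modest decrease, a decrease of the same direction is expected, and the step from compound 3 to compound 4 is estimated as a number 21.6 percentage points lower from compound 3 to compound 4 (beyond the scatter). Compound 4 is therefore expected to give about 55% in this assay, with a plausible range from 30% to 80%; the wide range reflects that the place of the change is not the same as in the measured pair.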

Compound 4, a percentage reported as inhibition, at one concentration (the size of the read-out at that concentration, not a potency): 25.4%
The estimate for compound 4 lay 29.6 percentage points above the measured number; the measured number lies below the stated range.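

In this assay, ethyl in place of hydrogen on a saturated chain carbon bound to an amide-type nitrogen gives a number 51.2 percentage points lower from compound 3 to compound 4 (beyond the scatter) and counts as a large step, which leaves compound 4 at 25.4% against the much higher number of its parent. The direction of the earlier step holds on the second core, but its size does not carry over: the same change on two cores in this assay, a number 23.4 percentage points lower (beyond the scatter) from compound 1 to compound 2 and a number 51.2 percentage points lower (beyond the scatter) from compound 3 to compound 4, 27.9 percentage points apart, beyond the scatter of two such steps. This rests on two pairs only, which differ both in the core and in the place of the change, so the gap cannot be assigned to one or the other, and neither the direction nor the size is established as a rule for the series, while each number remains a read-out at one concentration and not a potency.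

Still open, from the compounds shown here alone, is how the read-out behaves with other groups at the place changed from methyl to propyl in compound 4, such as a butyl chain, a cyclopropyl ring or a chain ending in a carboxylic acid, which would show whether the fall continues, levels off or reverses. Also open, going by these compounds, is whether the same change at the same place on both cores would give steps of similar size.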